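The source may report more compounds than this note shows. Statements on the series, on what has been measured and on what is new or still open speak of the compounds shown alone.

Compound 1 `CC(C)=CCC/C(C)=C/CC/C(C)=C/CSC[C@H](NC(=O)OC(C)(C)C)C(=O)C=[N+]=[N-]` and compound 3 `CC(C)=CCC/C(C)=C/CC/C(C)=C/CSC[C@H](NC(=O)OC(C)(C)C)C(=O)CCl` share one core, and compound 2 `CCCCCCCCCCCCSC[C@H](NC(C)=O)C(=O)C=[N+]=[N-]` and compound 4 `CCCCCCCCCCCCSC[C@H](NC(C)=O)C(=O)CCl` share another; the difference between the two cores is not broken down here. In a functional assay on NALM-6 cells (Homo sapiens) (a lower number here means a stronger inhibitor, a higher number a weaker inhibitor), compound 1 gives 49800 nM. Compound 3 gives 10700 nM in this assay. Between them lies one change, (a group of 2 heavy atoms (1 carbon, 1 chlorine; no ring) in place of a group of 3 heavy atoms (1 carbon, 2 nitrogen; no ring), on a carbonyl carbon), and that change made a 4.7-fold lower number from compound 1 to compound 3 (0.67 log units; beyond the scatter). In this assay compound 2 gives 15400 nM, which stands near the number for compound 3 and well away from that for compound 1. Compound 4 is not yet measured. It differs from compound 2 by a group of 2 heavy atoms (1 carbon, 1 chlorine; no ring) in place of a group of 3 heavy atoms (1 carbon, 2 nitrogen; no ring), on a carbonyl carbon, the same change seen before, made at a place described in the same words. A newcomer can read this as a repeat: the same small exchange on a carbonyl carbon, now on the second core. Because the earlier step was a 4.7-fold lower number from compound 1 to compound 3 (0.67 log units; beyond the scatter), a step of similar size is expected here, a 4.4-fold lower number from compound 2 to compound 4 (0.64 log units; beyond the scatter) in this assay, though it rests on a single prior example and a different core. Compound 4 is therefore estimated at 3500 nM, between 1500 nM and 8000 nM.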

Compound 4, half-maximal inhibitory concentration: 2000 nM
For compound 4 the middle estimate is 1.8-fold (0.24 log units) above the measured one, and the stated range covers the measured number.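

In this assay, chloromethyl in place of the nitrogen-bearing group on the carbonyl carbon gave a 7.7-fold lower number from compound 2 to compound 4 (0.89 log units; beyond the scatter), and this step matches the one seen on the other core: the same change on two cores in this assay, a 4.7-fold lower number (0.67 log units; beyond the scatter) from compound 1 to compound 3 and a 7.7-fold lower number (0.89 log units; beyond the scatter) from compound 2 to compound 4, 1.7-fold (0.22 log units) apart, within the scatter of two such steps. On these two cores, then, the change carried over at a similar size, and in both pairs the chloromethyl compound has the lower number, with neither pair going against this. For the compounds shown here, it does not show that the step would hold on a third core, since it rests on only two pairs in a single cell assay, and it does not say why the number falls.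

The compounds shown leave open how other groups on the carbonyl carbon, such as bromomethyl or fluoromethyl, would compare with chloromethyl. They also leave open whether the step would survive on a core with a shorter saturated chain or with a free amine in place of the capped nitrogen.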